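The source may hold more compounds than are shown below. What is called first, only, known or untested is meant among the compounds shown, and "the series" means these compounds.

All three measured compounds share one core, seen in compound 3 `COc1ccc(C#Cc2ccc(C(=O)N3CCC(CO)C3)cc2)cc1`, which in a functional assay on TREX cells for negative allosteric modulation of metabotropic glutamate receptor 3 (Rattus norvegicus), read by calcium flux, with a stated time of 2.5 min (a lower number here means a stronger inhibitor, a higher number a weaker inhibitor), gives 7590 nM. Compound 1 `COc1ccc(C#Cc2ccc(C(=O)N3CCC[C@@H](CO)C3)cc2)c(F)c1` carries one fluoro group on the aromatic ring that bears the methoxy group; in this assay compound 1 reaches only > 10000 nM, a limit of the assay and not a number. Compound 2 `COc1ccc(C#Cc2ccc(C(=O)N3CCC[C@@H](CO)C3)cc2)c(F)c1F` carries two fluoro groups on that ring. In this assay compound 2 likewise gives > 10000 nM, again a limit, so where compound 2 stands is known only as a limit. The step that the two limits leave unreadable from compound 1 to compound 2 is thus unreadable, as the limit of > 10000 nM in this assay, at which 2 of the 3 values shown sit, leaves both ends open.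

Compound 4 `COc1ccc(C#Cc2ccc(C(=O)N3CCC[C@@H](CO)C3)cc2)cc1F` arises from compound 2 by the change (hydrogen in place of fluoro on an aromatic carbon). Going by the values given here, the only measured step of the same kind, from compound 1 to compound 2, is the reverse change at another position and its size cannot be read, so no measured step tells how large a step in this assay should be. Compound 3, lacking both fluoro groups, gives only 7590 nM. One added fluoro group in compound 1 still left compound 1 at the limit of the assay. Compound 4 is therefore expected to stay weak, with an expected step that the limit leaves unreadable from compound 2 to compound 4 and an estimated value of 12000 nM, within 4000 nM to 40000 nM.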

Compound 4, half-maximal inhibitory concentration: > 10000 nM
Compound 4: a limit, no number; the forecaster's own chance of this, stated with the estimate: 55%; the middle value lies beyond the limit too.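

In this assay compound 4 gives > 10000 nM, a limit of the assay and not a number. The steps among compound 1, compound 2 and compound 4 cannot be read, because all three rest on the same limit: the limit of > 10000 nM in this assay, at which 3 of the 4 values shown sit. The compounds shown leave open whether fluoro groups on the methoxy-bearing ring change the inhibition at all.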